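The compounds below may be only part of what the source reports. "The series", "measured", "known", "first", "only" and "open" are said of these compounds alone.

Compound 1 `Cc1cc(S(=O)(=O)Nc2nc3cscc3c(=O)n2Cc2ccccc2)c(S)cc1Cl` and compound 2 `Cc1cc(S(=O)(=O)Nc2nc3ccsc3c(=O)n2Cc2ccccc2)c(S)cc1Cl` share one core and differ only in how its fused rings are joined. In a functional assay on HOP-62 cells (Homo sapiens) for inhibition (on this read-out lower numbers stand for stronger inhibition of growth and higher numbers for weaker inhibition of growth), compound 1 gives 16500 nM. In this assay compound 2 gives 19700 nM, the higher of the two numbers, yet within the scatter of compound 1, so the two cannot be told apart. Compound 3 `Cc1cc(S(=O)(=O)Nc2nc3cc(-c4ccccc4)sc3c(=O)n2Cc2ccccc2)c(S)cc1Cl` carries phenyl in place of hydrogen on an aromatic carbon. Going by the values given here, no measured pair shows what such a change does, so only a modest step, if any, is expected: a 1.5-fold lower number from compound 2 to compound 3 (0.18 log units; within the scatter). Compound 3 is therefore estimated at 13000 nM, between 4000 nM and 45000 nM.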

Compound 3, concentration for 50% growth inhibition: > 100000 nM
Compound 3: a limit, no number (the forecaster's own chance of this, stated with the estimate: 10%); middle value at least 7.6-fold (0.88 log units) away from the limit.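

Phenyl cannot simply replace hydrogen on this aromatic carbon, next to the ring sulfur, without a cost: the change gives an at least 5.0-fold higher number from compound 2 to compound 3 (0.70 log units; beyond the scatter), so inhibition of growth in this assay weakens. Compound 3 stands at a limit of the assay, not at a number: the limit of > 100000 nM in this assay, at which 1 of the 3 values shown sits. Going by these compounds, the full size of the step therefore stays unknown.

On these data alone, whether a methyl group or an amine on this same carbon would weaken inhibition too remains open. So does whether a phenyl group elsewhere on the shared core would have the same effect.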